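Sulfamide-piperidine series: moving the methoxy group on the aryl ring

This account rests on a few compounds, and the source may have more. Where it says the series, first, only, none or still open, it means among the compounds named here.

Measured compounds:
- compound 1, `COc1ccccc1-c1cc(N2CCC(CNS(N)(=O)=O)CC2)ncn1`, in a functional assay on M21 cells (Homo sapiens) for antiproliferative activity, read by sulforhodamine B assay, with a stated time of 48 h (on this read-out higher numbers stand for weaker inhibition of growth and lower numbers for stronger inhibition of growth), compound 1 gives > 100000 nM, which is a limit of the assay and not a number.
- compound 2, `NS(=O)(=O)NCCC1CCN(c2cc(-c3ccccc3)ncn2)CC1`, in this assay compound 2 gives > 100000 nM, again a limit rather than a number.
- compound 3, `COc1ccc(-c2cc(N3CCC(CCNS(N)(=O)=O)CC3)ncn2)cc1`, in this assay compound 3 gives 69800 nM.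

For the measured compounds named here, compound 3 is therefore the only member of the set with an actual number; the other two sit at the limit of > 100000 nM in this assay, at which 2 of the 3 values shown sit. Going by the values given here, the single measured step runs an at least 1.4-fold lower number from compound 2 to compound 3 (0.15 log units; that floor lies within the scatter), and its floor lies within the scatter, so it gives no firm direction.

Compound 4, `COc1ccccc1-c1cc(N2CCC(CCNS(N)(=O)=O)CC2)ncn1`, is the next candidate. It differs from compound 3 by 2-methoxyphenyl in place of 4-methoxyphenyl on an aromatic carbon. Among the compounds with values here, no measured step in the set compares these two aryl patterns directly, and the one step available says little about a positional swap of the same group. Compound 1, which also carries the 2-methoxyphenyl, shows only a limit, but it differs from compound 4 in a second place, so only its value can be noted, not a step. With nothing pointing clearly one way, no step beyond the scatter is expected, and a limit is a real possibility.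

Compound 4 is estimated in this assay at 100000 nM, with a range from 40000 nM to 300000 nM. This estimate means a step of a 1.4-fold higher number from compound 3 to compound 4 (0.16 log units; within the scatter), expected to stay within the scatter.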

Compound 4, concentration for 50% growth inhibition: 96900 nM
Estimate against measurement, compound 4: 1.0-fold (0.01 log units) above, within the range that was stated.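

In this assay, for the compounds shown here, the first direct comparison of the two aryl patterns, 2-methoxyphenyl in place of 4-methoxyphenyl on an aromatic carbon, gives a 1.4-fold higher number from compound 3 to compound 4 (0.14 log units; within the scatter) and so does not separate these two methoxy placements on this read-out. The 2-methoxyphenyl group now also has an actual number in compound 4, whereas compound 1 showed only a limit of the assay. Methoxy in place of hydrogen on an aromatic carbon gives an at least 1.0-fold lower number from compound 2 to compound 4 (0.01 log units; that floor lies within the scatter) and (sulfamoylamino)methyl in place of sulfamoylamino on a saturated chain carbon bound to a saturated ring carbon gives an at least 1.0-fold lower number from compound 1 to compound 4 (0.01 log units; that floor lies within the scatter) and neither step can be read, since each starts from a limit of the assay: the limit of > 100000 nM in this assay, at which 2 of the 4 values shown sit.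

On these data alone, whether a hydroxyl or a chlorine on the aryl ring, or a longer chain ahead of the sulfamoylamino group, would give a step beyond the scatter remains open. Also open, as far as these compounds go, is whether any change on this core gives values well clear of the limit.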